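This account rests on a few compounds, and the source may have more. Where it says the series, first, only, none or still open, it means among the compounds named here.

The series rests on a shared core, shown in compound 1 `COC(=O)[C@@]1(C)CCC=C2[C@@H]1CC[C@@H](C)[C@]2(C)Cc1c[nH]c2c(C)cccc12`, which in a functional assay on T47D cells (Homo sapiens) for inhibition, read by sulforhodamine B assay, with a stated time of 48 h (a lower number here means a stronger inhibitor of growth, a higher number a weaker inhibitor of growth), gives 18000 nM. Compound 2 `COC(=O)[C@@]1(C)CCC=C2[C@@H]1CC[C@@H](C)[C@]2(C)Cc1c[nH]c2c(Br)cccc12` carries the change bromo in place of methyl on an aromatic carbon and in this assay gives 24000 nM, so that the step of a 1.3-fold higher number from compound 1 to compound 2 (0.12 log units; within the scatter) is small. Compound 3 `COC(=O)[C@@]1(C)CCC=C2[C@@H]1CC[C@@H](C)[C@]2(C)Cc1c(C)[nH]c2c(C)cccc12` differs from compound 1 by methyl in place of hydrogen on an aromatic carbon, and in this assay compound 3 gives 19000 nM, with the step of a 1.1-fold higher number from compound 1 to compound 3 (0.02 log units; within the scatter) again small.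

Compound 4 `COC(=O)[C@@]1(C)CCC=C2[C@@H]1CC[C@@H](C)[C@]2(C)Cc1c(C)[nH]c2c(Br)cccc12` is not yet measured. It stands to compound 3 as compound 2 stands to compound 1, through (bromo in place of methyl on an aromatic carbon), the same change as before, at the same place in words. Because the earlier step of a 1.3-fold higher number from compound 1 to compound 2 (0.12 log units; within the scatter) stayed within the scatter, a similarly small step is expected here, a 1.3-fold higher number from compound 3 to compound 4 (0.10 log units; within the scatter), in this assay. The estimate for compound 4 in this assay is therefore 24000 nM, with a likely range from 12000 nM to 48000 nM.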

Compound 4, concentration for 50% growth inhibition: 31000 nM
Compound 4: middle estimate off by 1.3-fold (0.11 log units), on the low side; the measured number falls inside the stated range.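

Read in this assay, compound 4 adds two steps, a 1.6-fold higher number from compound 3 to compound 4 (0.21 log units; within the scatter) and a 1.3-fold higher number from compound 2 to compound 4 (0.11 log units; within the scatter); all of the steps lie within the scatter, so the four compounds show only that neither change moves the number measurably on these two cores, not that either change has a real effect of its own or that this would hold on any further core. The change of methyl to bromo carries from one core to the other without a difference that can be told apart: the same change on two cores in this assay, a 1.3-fold higher number (0.12 log units; within the scatter) from compound 1 to compound 2 and a 1.6-fold higher number (0.21 log units; within the scatter) from compound 3 to compound 4, 1.2-fold (0.09 log units) apart, within the scatter of two such steps. The same holds for the added methyl: the same change on two cores in this assay, a 1.1-fold higher number (0.02 log units; within the scatter) from compound 1 to compound 3 and a 1.3-fold higher number (0.11 log units; within the scatter) from compound 2 to compound 4, 1.2-fold (0.09 log units) apart, within the scatter of two such steps.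

The compounds shown leave open whether a different group on that aromatic carbon, such as an amine, a carboxylic acid or a longer chain, would shift the number beyond the scatter. They also leave open whether the two cores would still respond alike to a change that has a large step on either one.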